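The source may report more compounds than this note shows. Statements on the series, on what has been measured and on what is new or still open speak of the compounds shown alone.

Compound 1 `CN1CCN(C(=O)/C=C/c2ccncc2-c2ccc3ccccc3c2)CC1` was tested in a functional assay on A549 cells (Homo sapiens) for inhibition, read by sulforhodamine B assay, with a stated time of 72 h; a lower number here means a stronger inhibitor of growth, a higher number a weaker inhibitor of growth. In this assay compound 1 gives > 10000 nM, which is a limit of the assay and not a number. Compound 2 `Cn1ccc2cc(-c3cnccc3/C=C/C(=O)O)ccc21` in this assay gives > 10000 nM, likewise a limit rather than a number. Compound 1 therefore stands at the limit of > 10000 nM in this assay, at which 2 of the 2 values shown sit. Compound 3 `O=C(/C=C/c1ccncc1-c1ccc2ccccc2c1)NC1CC1` differs from compound 1 by cyclopropylamino in place of 4-methylpiperazin-1-yl on a carbonyl carbon. Going by the values given here, no step between measured compounds exists here, so one expects no shift beyond the usual scatter in this assay, an expected step that the limit leaves unreadable from compound 1 to compound 3. Compound 3 is estimated to give 15000 nM, within a range from 4000 nM to 60000 nM.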

Compound 3, concentration for 50% growth inhibition: 5840 nM
Compound 3: middle estimate off by 2.6-fold (0.41 log units), on the high side; the measured number falls inside the stated range.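

Compound 3 is the first compound shown with a readable number in this assay, so a change on this carbonyl carbon can bring growth inhibition within the range of the assay. Compound 1 gives > 10000 nM, which is a limit of the assay and not a number. Cyclopropylamino in place of 4-methylpiperazin-1-yl therefore gives only a floor, an at least 1.7-fold lower number from compound 1 to compound 3 (0.23 log units; that floor lies within the scatter), and that floor alone does not establish a real gain. From the compounds shown here alone, whether a plain amino group or a longer chain such as n-propylamino would behave like cyclopropylamino remains open. Also open, going by these compounds, is whether cyclopropylamino would give a readable number on the core of compound 2.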